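From quinolin-8-yl to quinolin-4-yl in compound 4

The source may hold more compounds than are shown below. What is called first, only, known or untested is meant among the compounds shown, and "the series" means these compounds.

For the measured compounds named here, in an ADME assay on SNB-19 cells (Homo sapiens) for cytotoxicity, read by MTT assay, with a stated time of 24 h (on this read-out lower numbers stand for higher toxicity in this test and higher numbers for lower toxicity in this test), compound 3 (`C=C1CC[C@@H]2[C@](C)(CO)[C@H](O)CC[C@@]2(C)[C@@H]1C/C=C1/C(=O)OC[C@@H]1Oc1cccc2cccnc12`) gives 22700 nM as the lowest of the three numbers so far. Compound 2 (`C=C1CC[C@@H]2[C@](C)(COC(C)=O)[C@H](O)CC[C@@]2(C)[C@@H]1C/C=C1/C(=O)OC[C@@H]1Oc1cccc2cccnc12`) gives 49500 nM and compound 1 (`C=C1CC[C@@H]2[C@](C)(CO)[C@H](O)CC[C@@]2(C)[C@@H]1C/C=C1/C(=O)OC[C@H]1Oc1cccnc1[N+](=O)[O-]`) gives 67700 nM as the two higher numbers. Compound 4 (`C=C1CC[C@@H]2[C@](C)(CO)[C@H](O)CC[C@@]2(C)[C@@H]1C/C=C1/C(=O)OC[C@@H]1Oc1ccnc2ccccc12`) has the same atoms as compound 3 joined differently (quinolin-4-yl in place of quinolin-8-yl on an oxygen on a saturated carbon) with quinolin-4-yl in place of quinolin-8-yl on an oxygen on a saturated carbon. Going by the values given here, the only measured step (a 2.2-fold lower number from compound 2 to compound 3 (0.34 log units; beyond the scatter)) is hydrogen in place of acetyl, a different change, so no measured step speaks directly to this swap. The estimate therefore means a 1.2-fold higher number from compound 3 to compound 4 (0.09 log units; within the scatter) and no shift beyond the scatter is expected. In this assay compound 4 is estimated at 28000 nM within a range from 11000 nM to 70000 nM as its expected span.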

Compound 4, half-maximal cytotoxic concentration: 61200 nM
The estimate for compound 4 lay 2.2-fold (0.34 log units) below the measured number; low and high end bracket the measured number.
By their numbers in this assay, from the lowest: compound 3; then compounds 2, 4 and 1 (each within the scatter of the next).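

In this assay, quinolin-4-yl in place of quinolin-8-yl on an oxygen on a saturated carbon brings a 2.7-fold higher number from compound 3 to compound 4 (0.43 log units; beyond the scatter). For the compounds shown here, this shows that the number at this position depends on how the quinoline is attached, even with the same atoms, which the earlier compounds could not show. Nothing measured here gives a reason for the shift.

What the compounds shown leave open is whether an amine or a carboxylic acid on the quinolin-4-yl group would move the number further. They also leave open whether acetyl on the oxygen of the hydroxymethyl arm would act with quinolin-4-yl as it does with quinolin-8-yl.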